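Shifting an Amino Group: Compound 2 to Compound 3

A few compounds are considered here, and "the series" means these few. Any claim that something is new, unique, unknown or untested is made for them only; others in the source may bear on it.

Compound 1, `O=S(=O)(c1ccccc1)c1nc2ccccc2nc1Nc1ccccc1`, gives 590 nM in a functional assay on PC-3 cells (Homo sapiens) for cytotoxicity, read by MTT assay, with a stated time of 72 h; on this read-out higher numbers stand for weaker inhibition and lower numbers for stronger inhibition.
Compound 2, `Nc1ccc(Nc2nc3ccccc3nc2S(=O)(=O)c2ccccc2)cc1`, gives 5830 nM in this assay.

Going by the values given here, of the two numbers measured so far, compound 2 gives the higher one, so its inhibition is the weaker. Among the compounds with values here, the only measured step is a 9.9-fold higher number from compound 1 to compound 2 (0.99 log units; beyond the scatter), which shows that putting an amino group onto the outer phenyl ring of the shared core weakened the inhibition beyond the scatter.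

Compound 3, `Nc1cccc(Nc2nc3ccccc3nc2S(=O)(=O)c2ccccc2)c1`, is not yet measured. It differs from compound 2 by 3-aminophenyl in place of 4-aminophenyl on a nitrogen on an aromatic ring; the amino group is kept but sits elsewhere on the same ring. Within the data shown here, no measured pair shows the effect of moving this group rather than adding it, so the step from compound 1 to compound 2 bears on it only loosely: it tells that the presence of the amino group matters, not where it sits. The expectation is therefore a step of a 1.9-fold lower number from compound 2 to compound 3 (0.29 log units; within the scatter), a number near that of compound 2, with a wide range that reaches down toward compound 1. Compound 3 is thus estimated at 3000 nM, between 800 nM and 12000 nM.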

Compound 3, half-maximal inhibitory concentration: 2150 nM
For compound 3 the middle estimate is 1.4-fold (0.14 log units) above the measured one, and the stated range covers the measured number.
By their numbers in this assay, from the lowest: compound 1; then compound 3; then compound 2.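

In this assay, moving the amino group on the same ring is a change in its own right: 3-aminophenyl in place of 4-aminophenyl gives a shift beyond the usual scatter (a 2.7-fold lower number from compound 2 to compound 3 (0.43 log units; beyond the scatter)), so where the group sits matters, and not only whether it is present. The group still weakens inhibition in its new place (a 3.6-fold higher number from compound 1 to compound 3 (0.56 log units; beyond the scatter)), though the loss is smaller than the one seen with 4-aminophenyl (a 9.9-fold higher number from compound 1 to compound 2 (0.99 log units; beyond the scatter)), so the change of place recovers only part of what adding the group cost. No measurement shown here explains why these two placements differ, and no independent data on these compounds help to interpret the numbers.

From the compounds shown here alone, the three compounds cover only hydrogen and an amino group on this outer phenyl ring, so it remains open whether a hydroxyl, a methoxy or a dimethylamino group would show the same dependence on place. Going by these compounds, it is also open whether any group on this ring could give a lower number than compound 1, or whether the unsubstituted phenyl ring stays the best of such a series.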